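The source may report more compounds than this note shows. Statements on the series, on what has been measured and on what is new or still open speak of the compounds shown alone.

Of the compounds shown here, three built on one shared core have been measured in a functional assay on NCI-H460 cells (Homo sapiens) for antiproliferative activity, with a stated time of 48 h; on this read-out lower numbers stand for higher toxicity in this test and higher numbers for lower toxicity in this test. Compound 1 `Cc1cc(O)c(C2=NN(c3ccc(S(N)(=O)=O)cc3)C(c3ccccc3O)C2)cc1Cl` gives 9400 nM. Compound 2 `Cc1cc(O)c(C2=NN(c3ccc(S(N)(=O)=O)cc3)C(c3ccccc3Cl)C2)cc1Cl` gives 8210 nM, and the step of a 1.1-fold lower number from compound 1 to compound 2 (0.06 log units; within the scatter) shows that this swap on the aromatic carbon leaves the read-out essentially unchanged. Compound 3 `Cc1cc(O)c(C2=NN(c3ccc(S(N)(=O)=O)cc3)C(/C=C/c3ccccc3)C2)cc1Cl` gives 41300 nM, the highest of the three numbers, meaning the cells tolerate it best. The steps of a 4.4-fold higher number from compound 1 to compound 3 (0.64 log units; beyond the scatter) and a 5.0-fold higher number from compound 2 to compound 3 (0.70 log units; beyond the scatter) both arose when 2-phenylethenyl entered at the saturated ring carbon, and both raised the number by a modest amount.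

Compound 4 `COc1ccc(C2CC(c3cc(Cl)c(C)cc3O)=NN2c2ccc(S(N)(=O)=O)cc2)cc1OC` has not yet been measured. Its change from compound 3 is 3,4-dimethoxyphenyl in place of 2-phenylethenyl on a saturated ring carbon, which returns an aromatic ring to that carbon. The two measured steps onto 2-phenylethenyl both raised the number, so reversing that kind of change is expected to lower it again, though 3,4-dimethoxyphenyl differs from either aromatic group measured, widening the uncertainty. The expected step is a 4.1-fold lower number from compound 3 to compound 4 (0.62 log units; beyond the scatter). Compound 4 is therefore estimated at 10000 nM, with a range from 4000 nM to 30000 nM.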

Compound 4, concentration lethal to 50% of the cells: 22000 nM
Compound 4: middle estimate off by 2.2-fold (0.34 log units), on the low side, within the range that was stated.
By their numbers in this assay, from the lowest: compounds 2 and 1 (each within the scatter of the next); then compounds 4 and 3 (each within the scatter of the next).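

Putting an aromatic ring back on the saturated ring carbon does not by itself return the number to the level of compound 1 and compound 2: 3,4-dimethoxyphenyl cannot be told apart from 2-phenylethenyl (a 1.9-fold lower number from compound 3 to compound 4 (0.27 log units; within the scatter)), yet it stands clear of both 2-chlorophenyl (a 2.7-fold higher number from compound 2 to compound 4 (0.43 log units; beyond the scatter)) and 2-hydroxyphenyl (a 2.3-fold higher number from compound 1 to compound 4 (0.37 log units; beyond the scatter)). Among these compounds, then, the read-out at this position depends on what the attached aromatic ring carries, and not simply on whether the ring sits directly on that carbon. Nothing available explains this difference.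

Still open, as far as these compounds go, is whether a plain phenyl ring, or one with a single methoxy group, would group with compound 4 or with compound 1 and compound 2. The effect of an amine or a carboxylic acid on that ring is also unknown.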